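A few compounds are considered here, and "the series" means these few. Any claim that something is new, unique, unknown or untested is made for them only; others in the source may bear on it.

Working notes on the series.

Compound 3 `COc1ccc(F)cc1CNCCCNc1ccnc2cc(-c3ccccc3)ccc12` gives 2960 nM in an ADME assay on HepG2 cells (Homo sapiens) for cytotoxicity, read by luminescence, CellTiter-Glo and ATP content, with a stated time of 72 h; a higher number here means that more compound is needed for the effect, a lower number that less compound is needed. Among the three compounds measured so far it holds the second highest number: compound 2 `COc1ccc(F)cc1CNCCCNc1ccnc2cc(C3CCCCC3)ccc12` gives 2290 nM, and compound 1 `c1ccc(Oc2ccc3c(NCCCNCc4ccco4)ccnc3c2)cc1` gives 15200 nM. Among the measured compounds shown here, the single one-point step within the measured set, a 1.3-fold higher number from compound 2 to compound 3 (0.11 log units; within the scatter), shows that exchanging the group on that aromatic carbon between cyclohexyl and phenyl leaves the read-out unmoved.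

Compound 4 `COc1ccc(F)cc1CNCCCNc1ccnc2cc(Oc3ccccc3)ccc12` is the next member to be measured. It differs from compound 3 as follows: phenoxy in place of phenyl on an aromatic carbon. For the measured compounds named here, no measured step covers this exact change. Compound 1 also carries a phenoxy group at that aromatic carbon, but it differs from compound 3 in the amine side chain as well, so its pair with compound 3 only shows that the phenoxy-bearing compound 1 sits at the higher end of the range seen so far. The step from compound 2 to compound 3 speaks for a tolerant position, which argues against a large move.

On balance the expectation for compound 4 is a modest rise in the number, a 1.7-fold higher number from compound 3 to compound 4 (0.23 log units; within the scatter), with an estimated value of 5000 nM and a likely range from 2000 nM to 13000 nM.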

Compound 4, half-maximal effective concentration: 1500 nM
The estimate for compound 4 lay 3.3-fold (0.52 log units) above the measured number; measured number below the stated range.
By their numbers in this assay, from the lowest: compounds 4, 2 and 3 (each within the scatter of the next); then compound 1.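

With phenoxy common to both compounds, a 10-fold lower number from compound 1 to compound 4 (1.01 log units; beyond the scatter) in this assay, a step that belongs to 5-fluoro-2-methoxyphenyl in place of furan-2-yl on the saturated chain carbon bound to an amine nitrogen. The high number of compound 1 therefore cannot be read as a mark of the phenoxy group, and this side-chain change is the only one so far with a step beyond the scatter. On the aromatic carbon, a 2.0-fold lower number from compound 3 to compound 4 (0.30 log units; within the scatter) and a 1.5-fold lower number from compound 2 to compound 4 (0.18 log units; within the scatter), so these steps join a 1.3-fold higher number from compound 2 to compound 3 (0.11 log units; within the scatter) in showing that cyclohexyl, phenyl and phenoxy cannot be told apart at this position, and no data on any property of these compounds offer an explanation for either finding.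

The compounds shown leave open whether this tolerance extends beyond these three six-membered ring groups, for example to a carboxylic acid or an amine on the same aromatic carbon. They also leave open whether the side-chain step recurs with phenyl or cyclohexyl on the aromatic carbon, and how a longer chain in the amine side chain would read.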